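Sigma-1 binding: dropping the methyl from compound 3

The source may hold more compounds than are shown below. What is called first, only, known or untested is meant among the compounds shown, and "the series" means these compounds.

Series notes. Compound 1 `CC(C)c1ccc(-c2nc(CN3CCCC3)nn2C)cc1` in an assay on membranes from Jurkat cells for displacement of a labelled ligand from Sigma non-opioid intracellular receptor 1 (Homo sapiens), read by scintillation counting, with a stated time of 2 h (on this read-out higher numbers stand for weaker inhibition and lower numbers for stronger inhibition), gives 96 nM; compound 2 `Cn1nc(CN2CCCC2)nc1-c1ccc(-c2ccccc2)cc1` in this assay gives 90 nM, and the step of a 1.1-fold lower number from compound 1 to compound 2 (0.03 log units; within the scatter) is within the scatter. Compound 3 `Cc1cc(-c2nc(CN3CCCC3)nn2C)ccc1C(F)(F)F` in this assay gives 21 nM, the lowest number of the three measured compounds, with compound 2 and compound 1 both standing beyond the scatter above it, so compound 3 is the strongest binder seen so far.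

Compound 4 `Cn1nc(CN2CCCC2)nc1-c1ccc(C(F)(F)F)cc1` differs from compound 3 by hydrogen in place of methyl on an aromatic carbon. Among the measured compounds shown here, no measured pair changes this position; the only measured step, a 1.1-fold lower number from compound 1 to compound 2 (0.03 log units; within the scatter), alters the large group and does not bear on it. With the trifluoromethyl group kept and only the methyl removed, compound 4 is expected to sit between compound 3 and the two compounds lacking trifluoromethyl, so a modest weakening is estimated, a 1.9-fold higher number from compound 3 to compound 4 (0.28 log units; within the scatter). The estimate for compound 4 in this assay is therefore 40 nM, expected between 15 nM and 110 nM.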

Compound 4, inhibition constant: 82 nM
For compound 4 the middle estimate is 2.1-fold (0.31 log units) below the measured one; low and high end bracket the measured number.
By their numbers in this assay, from the lowest: compound 3; then compounds 4, 2 and 1 (each within the scatter of the next).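

In this assay, among the compounds shown here, the methyl ortho to a trifluoromethyl group counts: hydrogen in its place gives a 3.9-fold higher number from compound 3 to compound 4 (0.59 log units; beyond the scatter), the first measured change at this position and the first step beyond the scatter. Without that methyl, the trifluoromethyl group is not told apart from phenyl, with a 1.1-fold lower number from compound 2 to compound 4 (0.04 log units; within the scatter), or from isopropyl, with a 1.2-fold lower number from compound 1 to compound 4 (0.07 log units; within the scatter), both within the scatter, so trifluoromethyl alone does not account for the low number of compound 3. Nothing at hand bears on why this methyl matters.

Going by these compounds, whether ethyl, methoxy or chlorine on this aromatic carbon would match methyl remains open. So does whether methyl at the corresponding place would give a step of similar size with phenyl or isopropyl in place of trifluoromethyl.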